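Trimming the benzyl group to methyl on the amide nitrogen

This account rests on a few compounds, and the source may have more. Where it says the series, first, only, none or still open, it means among the compounds named here.

Measured so far:
compound 1 `O=C(O)CN(C(=O)CCc1nc2c(F)c(F)cc(F)c2s1)c1ccccc1`: 54%
compound 2 `O=C(O)CN(Cc1ccccc1)C(=O)CCc1nc2c(F)c(F)cc(F)c2s1`: 75%

In a functional assay on the whole organism (Sciatic nerve) for inhibition, with Rattus norvegicus as the target, at a dose of 30 mg/kg by the oral route (on this read-out lower numbers stand for less inhibition and higher numbers for more inhibition at the one dose given (going by the name of the read-out)), compound 1 gives 54%, while compound 2 gives 75%. Among the measured compounds shown here, compound 2 thus stands higher of the two, the only measured step being a number 21 percentage points higher from compound 1 to compound 2 (beyond the scatter).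

Compound 3 `CN(CC(=O)O)C(=O)CCc1nc2c(F)c(F)cc(F)c2s1` is the next variation: hydrogen in place of phenyl on a saturated chain carbon bound to an amide-type nitrogen. Read one bond further out, the change is benzyl to methyl.

For the measured compounds named here, no measured step covers this exact change. Going by the values given here, the one step available shows that adding a saturated carbon between the amide nitrogen and the phenyl raised inhibition; removing the phenyl altogether is a different move, so its guidance is indirect, and a fall below compound 2 seems the more likely outcome, with wide uncertainty. Compound 3 is therefore expected to give about 50%, with a range from 25% to 75%. This estimate corresponds to an expected step of a number 25 percentage points lower from compound 2 to compound 3 (beyond the scatter).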

Compound 3, a percentage reported as inhibition, in the whole organism at one dose (the size of the read-out at that dose, not a potency): 61%
Compound 3: the middle estimate sits 11 percentage points below what was measured, within the range that was stated.
By their numbers in this assay, from the lowest: compounds 1 and 3 (each within the scatter of the next); then compound 2.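

In this assay, the change from benzyl to methyl gives a number 14 percentage points lower from compound 2 to compound 3 (beyond the scatter), so the phenyl at the end of the benzyl group contributes to the read-out at this position, although compound 3 without that ring still gives 61%. Placing phenyl directly on the amide-type nitrogen instead of methyl gives a number 7 percentage points higher from compound 1 to compound 3 (within the scatter), so these two groups cannot be told apart here, and only the benzyl of compound 2 stands clearly apart from both. Nothing available explains why the benzyl group behaves differently from the other two.

On these data alone, it remains open whether a phenethyl group, with its longer chain, or a cyclohexylmethyl group, with a saturated ring in place of the phenyl, would match the benzyl group. These results come from one dose, so they also leave open how the compounds compare in potency.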